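Chloro to Fluoro on the Benzyl Group: Expecting Little Change

The compounds below may be only part of what the source reports. "The series", "measured", "known", "first", "only" and "open" are said of these compounds alone.

Compound 1, `CC1=C(C(=O)Nc2ccc(F)cc2)C(c2ccc([N+](=O)[O-])cc2)N=C(SCc2ccc(Cl)cc2)N1`, gives 6.7% in a functional assay on the whole organism (artery, strain albino) with Rattus norvegicus as the target, with a stated time of 30 min, at a dose of 10 mg/kg by the oral route; on this read-out higher numbers stand for more inhibition at the one dose given (going by the name of the read-out) and lower numbers for less inhibition.
Compound 2, `CC1=C(C(=O)Nc2ccc(F)cc2)C(c2ccc([N+](=O)[O-])cc2)N=C(SCc2ccc(F)cc2)N1`, gives 5.7% in this assay.
Compound 3, `CC1=C(C(=O)Nc2ccc([N+](=O)[O-])cc2)C(c2ccc(Br)cc2)N=C(SCc2ccc(Cl)cc2)N1`, gives 6.2% in this assay.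

Compound 1 and compound 3 differ in more than one place, and the difference between the two cores is not broken down here. Compound 2 carries one change against compound 1: fluoro in place of chloro on an aromatic carbon. That change gave a number 1 percentage points lower from compound 1 to compound 2 (within the scatter). Compound 4, `CC1=C(C(=O)Nc2ccc([N+](=O)[O-])cc2)C(c2ccc(Br)cc2)N=C(SCc2ccc(F)cc2)N1`, stands to compound 3 as compound 2 stands to compound 1, with the same change at the same place: fluoro in place of chloro on an aromatic carbon. The step from compound 3 to compound 4 in this assay is expected to be a number 0.7 percentage points lower from compound 3 to compound 4 (within the scatter), because the earlier step was a number 1 percentage points lower from compound 1 to compound 2 (within the scatter). Compound 4 is therefore estimated at 5.5%, with a range from 0% to 13%.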

Compound 4, a percentage reported as inhibition, in the whole organism at one dose (the size of the read-out at that dose, not a potency): 5.2%
Compound 4: middle estimate off by 0.3 percentage points, on the high side; low and high end bracket the measured number.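

In this assay the exchange of 4-chlorobenzyl for 4-fluorobenzyl gave a number 1 percentage points lower from compound 3 to compound 4 (within the scatter), and the step reads the same on both cores: the same change on two cores in this assay, a number 1 percentage points lower (within the scatter) from compound 1 to compound 2 and a number 1 percentage points lower (within the scatter) from compound 3 to compound 4, 0 percentage points apart, within the scatter of two such steps The change therefore carried over between these two cores with no difference that can be told from the scatter. This does not show that the change has any effect on either core, and two cores set no rule for the whole series.

The compounds shown leave open whether another group on the same aromatic carbon, such as methoxy, trifluoromethyl or an amine, would move the number beyond the scatter. They also leave open whether the fluoro for chloro step would stay the same on a core carrying a carboxylic acid.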